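The compounds below may be only part of what the source reports. "The series", "measured", "known", "first", "only" and "open" are said of these compounds alone.

In a functional assay on K562 cells (Homo sapiens) for antiproliferative activity, read by MTT assay, with a stated time of 72 h (a higher number here means a weaker inhibitor, a lower number a stronger inhibitor), compound 1 `COc1ccc(-c2ncnn2-c2cc(OC)c(OC)c(OC)c2)cc1` gives 950 nM. Compound 2 `COc1cc(-n2ncnc2-c2ccc(Cl)c(Cl)c2)cc(OC)c1OC` reads > 10000 nM, which is a limit and not a number. Compound 3 `COc1cc(-n2ncnc2-c2cccc(F)c2)cc(OC)c1OC` reads > 10000 nM, also a limit, and so it stands at the limit of > 10000 nM in this assay, at which 2 of the 3 values shown sit.

The step to follow leads from there to compound 4 `COc1ccccc1-c1ncnn1-c1cc(OC)c(OC)c(OC)c1`, with the change (2-methoxyphenyl in place of 3-fluorophenyl on an aromatic carbon). This puts 2-methoxyphenyl in place of 3-fluorophenyl, so compound 4 again carries a methoxyphenyl group, though not the 4-methoxyphenyl of compound 1.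

Within the data shown here, two measured steps bear on this change, and both are large. Replacing the 4-methoxyphenyl gave an at least 10-fold higher number from compound 1 to compound 3 (1.02 log units; beyond the scatter), and the second replacement, with 3,4-dichlorophenyl, gave an at least 10-fold higher number from compound 1 to compound 2 (1.02 log units; beyond the scatter). Read in reverse, the first of these suggests that restoring a methoxyphenyl group could bring a clearly lower number, since compound 1 reaches 950 nM. Among the measured compounds shown here, no measured compound carries 2-methoxyphenyl, however, so the recovery may be only partial, and compound 4 may yet remain at the limit in this assay.

The expected change is an at least 2.8-fold lower number from compound 3 to compound 4 (0.45 log units; beyond the scatter), towards a lower number. Compound 4 is estimated at 3500 nM, with an expected range of 700 nM to 10000 nM.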

Compound 4, half-maximal inhibitory concentration: > 10000 nM
Compound 4: only a limit was reported (the forecaster's own chance of this, stated with the estimate: 40%); middle value at least 2.8-fold (0.45 log units) away from the limit.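

In this assay, a methoxyphenyl group on this aromatic carbon is not enough on its own: 2-methoxyphenyl in place of 4-methoxyphenyl gives an at least 10-fold higher number from compound 1 to compound 4 (1.02 log units; beyond the scatter). Among the compounds shown, only compound 1, with 4-methoxyphenyl, gives a number, while 3,4-dichlorophenyl, 3-fluorophenyl and 2-methoxyphenyl all end at the same limit, which is not a number: the limit of > 10000 nM in this assay, at which 3 of the 4 values shown sit. The steps among compound 2, compound 3 and compound 4 cannot be read, as each has a limit at both ends, so no order among these three can be stated.

The compounds shown leave open whether anything separates these three compounds, as the limit hides any difference between them, and so neither the dichloro, fluoro nor 2-methoxy change can be ranked against the others. They also leave open how closely the number of compound 1 depends on its methoxy group itself, which an ethoxy group, a hydroxyl group or an amine in its place on the 4-substituted phenyl ring would begin to answer.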